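Compound 3 and the step to compound 4

The source may hold more compounds than are shown below. What is called first, only, known or untested is meant among the compounds shown, and "the series" means these compounds.

Measured in a functional assay on the whole organism for inhibition, with Cavia porcellus as the target; a higher number here means that more compound is needed for the effect, a lower number that less compound is needed:
- compound 1 `COc1ccccc1OCC1SCCN1C(=O)CN`: 57 mg/kg
- compound 2 `COc1ccccc1OCC1SCCN1C(C)=O`: 46 mg/kg
- compound 3 `COc1ccccc1OCC1SCCN1C(=O)CC(=O)O`: 20 mg/kg

In this assay, compound 3 has the lowest number of the three. The next structure is compound 4 `COc1ccccc1OCC1SCCN1C(=O)CC(=O)NCc1ccncc1`, which keeps the shared core. Its change is ((pyridin-4-yl)methyl)amino in place of hydroxy on a carbonyl carbon.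

Among the measured compounds shown here, no measured step makes this exact change, so the evidence is indirect. The three measured steps all change a group on the saturated chain carbon bound to a carbonyl carbon. One stayed within the scatter, a 1.2-fold lower number from compound 1 to compound 2 (0.09 log units; within the scatter). The other two were modest, a 2.3-fold lower number from compound 2 to compound 3 (0.36 log units; beyond the scatter) and a 2.9-fold lower number from compound 1 to compound 3 (0.45 log units; beyond the scatter). For the measured compounds named here, with steps of that size as the only guide, a modest step is expected here too. Its direction is uncertain, but a higher number is more likely, since compound 3 already sits lowest at 20 mg/kg. The expected change is a 1.5-fold higher number from compound 3 to compound 4 (0.18 log units; within the scatter). For compound 4 the estimated value is 30 mg/kg, with an expected range from 11 mg/kg to 80 mg/kg.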

Compound 4, dose for half-maximal effect: 23 mg/kg
Beside the measured number, compound 4's estimate is 1.3-fold (0.12 log units) above it; measured number inside the range.
By their numbers in this assay, from the lowest: compounds 3, 4, 2 and 1 (each within the scatter of the next, the first and the last beyond it).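

In this assay, among the compounds shown here, the earlier steps all changed a group on the saturated chain carbon, whereas this one changes the group on a carbonyl carbon, and a 1.2-fold higher number from compound 3 to compound 4 (0.06 log units; within the scatter) is the result. Hydroxy, with 1 heavy atom, gives way to ((pyridin-4-yl)methyl)amino, with 8 heavy atoms and a six-membered aromatic ring, so this position takes a far larger group, and the loss of the free carboxylic acid, without a step beyond the scatter. Nothing available explains why the two numbers stay so close.

From the compounds shown here alone, whether the pyridine ring contributes at all remains open, since a benzylamino group or a plain methylamino group on the same carbonyl carbon would test this. A longer chain between the amide nitrogen and the pyridine ring is also an open question.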